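Double-bond geometry in the series: from compound 2 to compound 3

The source may hold more compounds than are shown below. What is called first, only, known or untested is meant among the compounds shown, and "the series" means these compounds.

Compound 1 `O=C1Nc2ccc([N+](=O)[O-])cc2/C1=C\c1cccc(OCc2cn(Cc3ccccc3)nn2)c1` has in a functional assay on DU-145 cells (Homo sapiens) for inhibition, read by MTT assay, with a stated time of 48 h (a lower number here means a stronger inhibitor, a higher number a weaker inhibitor), only the entry "not determined" (no result reported). Among the measured compounds shown here, compound 2 `CC(=O)c1ccc2c(c1)/C(=C/c1cccc(OCc3cn(Cc4ccccc4)nn3)c1)C(=O)N2` is thus the sole compound with a reading. In this assay compound 2 gives > 50000 nM, which is a limit of the assay and not a number. The change to compound 3 `CC(=O)c1ccc2c(c1)/C(=C\c1cccc(OCc3cn(Cc4ccccc4)nn3)c1)C(=O)N2` is the two compounds have the same atoms and bonds and differ only in configuration as drawn: 1 of 1 stereo elements differ; a double bond is drawn Z in compound 2 and E in compound 3. For the measured compounds named here, no step between measured compounds exists here, and compound 2 sits at the limit of > 50000 nM in this assay, at which 1 of the 2 values shown sits. Because compound 2 stands at the limit of > 50000 nM in this assay, at which 1 of the 2 values shown sits, compound 3 is expected to remain near that limit, a step of a number no higher from compound 2 to compound 3 (the limit leaves the size open) not beyond the scatter. The estimate for compound 3 is 50000 nM, with a range from 10000 nM to 200000 nM.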

Compound 3, half-maximal inhibitory concentration: > 50000 nM
Compound 3 gave a limit, no number (the forecaster's own chance of this, stated with the estimate: 70%); the middle value lies on the limit itself.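

Compound 2 and compound 3 both give a limit rather than a number in this assay, so no step can be read between them. On these data alone, whether the Z and E forms differ in this assay stays open.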